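The source may report more compounds than this note shows. Statements on the series, on what has been measured and on what is new or still open speak of the compounds shown alone.

Measured compounds:
- compound 1, `O=S(=O)(c1cccc(F)c1)c1cn(C2CCNC2)c2ncccc12`: 2.7 nM
- compound 2, `CCN1CCC(n2cc(S(=O)(=O)C3=C(Cl)NC4SC=CN34)c3cccnc32)C1`: 1.4 nM
- compound 3, `CC(C)N1CCCC(n2cc(S(=O)(=O)C3=C(Cl)NC4SC=CN34)c3cccnc32)C1`: 1.7 nM

Notes on the series. In an assay on HeLa cells for displacement of a labelled ligand from 5-hydroxytryptamine receptor 6 (Homo sapiens) (a lower number here means a stronger inhibitor, a higher number a weaker inhibitor), compound 1 gives 2.7 nM, compound 2 gives 1.4 nM and compound 3 gives 1.7 nM. Compound 3 stands second highest of the three numbers, but its nearest neighbour is compound 2 and the step of a 1.2-fold higher number from compound 2 to compound 3 (0.08 log units; within the scatter), so the two are indistinguishable; the gap to compound 1 is also within the scatter. All three compounds sit close together in this assay.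

Compound 4, `CC(C)N1CCCC(n2cc(S(=O)(=O)c3cccc(F)c3)c3cccnc32)C1`, is not yet measured. Compared with compound 3 the change is a group of 7 heavy atoms (6 carbon, 1 fluorine; one six-membered aromatic ring of carbon only) in place of a group of 9 heavy atoms (5 carbon, 2 nitrogen, 1 sulfur, 1 chlorine; 2 five-membered non-aromatic rings with 2 hetero atoms each), on a sulfonyl sulfur. Among the compounds with values here, no single measured step covers exactly this exchange: compound 1 already carries the 3-fluorophenyl on the sulfonyl sulfur, but it differs from compounds 2 and 3 at the aromatic nitrogen as well, so only the values themselves can be compared. Compound 1 with 2.7 nM and compound 3 with 1.7 nM lie within the scatter of each other, and the step of a 1.2-fold higher number from compound 2 to compound 3 (0.08 log units; within the scatter) shows the amine change on the aromatic nitrogen is likewise without effect beyond the scatter. The expectation for compound 4 is therefore a step of a 1.5-fold higher number from compound 3 to compound 4 (0.17 log units; within the scatter), that is, no change beyond the scatter in this assay. Compound 4 is estimated at 2.5 nM, within the range 1 nM to 6 nM.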

Compound 4, inhibition constant: 3.4 nM
Beside the measured number, compound 4's estimate is 1.4-fold (0.13 log units) below it; the range from low to high includes it.
By their numbers in this assay, from the lowest: compounds 2, 3, 1 and 4 (each within the scatter of the next, the first and the last beyond it).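

In this assay the exchange on the sulfonyl sulfur can now be read directly, with 1-isopropylpiperidin-3-yl held constant on the aromatic nitrogen: 3-fluorophenyl in place of the group of 9 heavy atoms gives a 2.0-fold higher number from compound 3 to compound 4 (0.30 log units; within the scatter) and so stays within the scatter. With 3-fluorophenyl held constant on the sulfonyl sulfur, 1-isopropylpiperidin-3-yl in place of pyrrolidin-3-yl on the aromatic nitrogen gives a 1.3-fold higher number from compound 1 to compound 4 (0.10 log units; within the scatter) and also stays within the scatter. Within the data shown here, each position has thus now been varied with the other held constant, and neither exchange separates its pair in this assay, even though the first replaces a group with a hydrogen-bond donor and 3 hydrogen-bond acceptors with one that has neither.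

Still open, going by these compounds, is whether the same holds for a pyridyl ring or a carboxylic acid on the sulfonyl sulfur, or for a cyclohexyl group, which has no ring nitrogen, on the aromatic nitrogen. No measurement shown here speaks to what lies behind these readings.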